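Isopropyl to Methyl on the Thiazole: Expected Half-Life

The source may report more compounds than this note shows. Statements on the series, on what has been measured and on what is new or still open speak of the compounds shown alone.

Measured compounds:
- compound 1, `Cc1cnc(NC(=O)CCCOc2cncc(Cl)c2)s1`: 0.333 h
- compound 2, `N#Cc1cnc(NC(=O)CCCOc2cccc(C(F)(F)F)c2)s1`: 1.33 h
- compound 3, `CC(C)c1cnc(NC(=O)CCCOc2ccccc2)s1`: 0.117 h

Of the compounds shown here, three sharing one core have been measured in an ADME assay on microsomes from liver (Homo sapiens) for metabolic stability, read by LC-MS, using NADPH, tested at 1 uM; on this read-out higher numbers stand for a longer-lived compound and lower numbers for a shorter-lived compound. Compound 3 gives 0.117 h, the lowest of the three numbers; compound 1 stands higher, and compound 2 stands higher still, both gaps lying beyond the usual scatter. Compound 4, `Cc1cnc(NC(=O)CCCOc2ccccc2)s1`, has not been measured. It differs from compound 3 in a single place: methyl in place of isopropyl on an aromatic carbon. For the measured compounds named here, no directly comparable pair of measured compounds carries this change, so the expectation rests on the values alone. Compound 1, which bears the methyl but a different tail, gives 0.333 h, and this is taken as a loose guide. The step of a 2.1-fold higher number from compound 3 to compound 4 (0.33 log units; beyond the scatter) is expected to be a modest rise, possibly just beyond the scatter. Compound 4 is therefore estimated at 0.25 h, with a range from 0.1 h to 0.6 h.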

Compound 4, half-life in the Homo sapiens assay: 0.167 h
Beside the measured number, compound 4's estimate is 1.5-fold (0.18 log units) above it; the measured number falls inside the stated range.
By their numbers in the Homo sapiens assay, from the lowest: compounds 3, 4 and 1 (each within the scatter of the next, the first and the last beyond it); then compound 2.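

With the rest of the structure unchanged, methyl in place of isopropyl on an aromatic carbon next to the ring sulfur gives, in the Homo sapiens assay, a 1.4-fold higher number from compound 3 to compound 4 (0.15 log units; within the scatter), so this read-out does not tell the two groups apart at this position. In a physicochemical assay for solubility, read by nephelometry, in phosphate buffer, at pH 6.5 (a higher number here means a more soluble compound, a lower number a less soluble compound), compound 3 gives < 1200 nM, which is a limit of the assay: the limit of < 1200 nM in the physicochemical assay, at which 1 of the 2 values shown sits. In the physicochemical assay compound 4 gives < 1100 nM, also a limit, so the step between the two compounds cannot be read: the limit of < 1100 nM in the physicochemical assay, at which 1 of the 2 values shown sits.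

The compounds shown leave open how a cyclopropyl group, a nitrile or a carboxylic acid at this position would read with the same tail. They also leave open whether a change in the tail would show more than this change does.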